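The compounds below may be only part of what the source reports. "The series", "measured", "known", "first", "only" and "open" are said of these compounds alone.

Measured so far in an assay on isolated protein for inhibition of Myeloperoxidase (Homo sapiens), with a stated time of 10 min; a lower number here means a stronger inhibitor, a higher number a weaker inhibitor:
compound 1 `Nc1cc(Cc2ccn(Cc3cccc(-c4ccccc4)c3)n2)c2nn[nH]c2n1` gives 55 nM
compound 2 `Nc1cc(Cc2ccn(Cc3ccc4cnccc4c3)n2)c2nn[nH]c2n1` gives 140 nM
compound 3 `Nc1cc(C2CCNCc3cccc(c3)Oc3cccc(c3)Cn3cc2cn3)c2nn[nH]c2n1` gives 36 nM

Compound 1 holds the second highest of the three numbers. Compound 3 lies closest to it, with a gap inside the usual scatter, so the two cannot be ordered. Compound 2 sits further off, with a gap beyond the scatter, so compound 2 is the weaker inhibitor of that pair.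

Compound 4 `Nc1cc(Cc2ccn(Cc3cccc(O[C@H]4CCNC4)c3)n2)c2nn[nH]c2n1` has not been measured in this assay. It differs from compound 1 in one place: (pyrrolidin-3-yl)oxy in place of phenyl on an aromatic carbon. For the measured compounds named here, no measured pair shows this change, and the remaining compounds alter other parts of the molecule, so the step has no direct precedent. Compound 3, whose large ring carries an ether oxygen and an amine, gives 36 nM, close to compound 1, which suggests that oxygen and amine on that part of the molecule are tolerated.

For compound 4 the step is expected to be a 1.6-fold higher number from compound 1 to compound 4 (0.21 log units; within the scatter), a modest change not clearly beyond the scatter. The estimate for compound 4 in this assay is 90 nM, with a range from 30 nM to 270 nM.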

Compound 4, half-maximal inhibitory concentration: 46 nM
Beside the measured number, compound 4's estimate is 2.0-fold (0.29 log units) above it; the range from low to high includes it.
By their numbers in this assay, from the lowest: compounds 3, 4 and 1 (each within the scatter of the next); then compound 2.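

In this assay, (pyrrolidin-3-yl)oxy in place of phenyl on an aromatic carbon, meta to a large group, gives a 1.2-fold lower number from compound 1 to compound 4 (0.08 log units; within the scatter). This single pair shows that, at this position, a six-membered aromatic ring of carbon only can give way to a five-membered non-aromatic ring with a hetero atom, attached through oxygen, with no change beyond the scatter. Nothing at hand accounts for the two groups reading alike.

The compounds shown leave open whether the ring nitrogen of the (pyrrolidin-3-yl)oxy group matters, a question that a tetrahydrofuran-3-yloxy group, with oxygen in that ring place, would address. Also open, going by these compounds, are the role of the defined stereocentre and how an open-chain aminoethoxy group would read at the same position.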